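This account rests on a few compounds, and the source may have more. Where it says the series, first, only, none or still open, it means among the compounds named here.

Working notes on the series.

Compound 1 `COc1ccc(CNC(=O)c2cc(-c3cncc(C)c3)ncc2-c2cnccn2)nc1OC` is the reference point. In an ADME assay on the whole organism for pharmacokinetics, with Canis familiaris (Canis lupus familiaris) as the target, using cassette dosing (on this read-out higher numbers stand for fast clearance and lower numbers for slow clearance), compound 1 gives 24 mL/min/kg, the lowest of the three numbers in hand. Compound 3 `COc1ccc(CNC(=O)c2nc(-c3cncc(C)c3)cnc2-c2ccccc2)nc1OC` gives 37 mL/min/kg in this assay, a value within the scatter of compound 1. Compound 2 `COc1ccc(CNC(=O)c2cc(-c3cncc(C)c3)ccc2-c2ccccc2)nc1OC` gives 51 mL/min/kg in this assay, and that gap to compound 1 lies beyond the scatter. Among the compounds with values here, compounds 2 and 3 differ from compound 1 in more than one place, so no single step between the measured compounds can be read off, and no link between one structural change and one shift in this assay is established by them.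

Compound 4 `COc1ccc(CNC(=O)c2cc(-c3cncc(C)c3)ncc2-c2ccccc2F)nc1OC` has not yet been measured. It differs from compound 1 by 2-fluorophenyl in place of pyrazin-2-yl on an aromatic carbon, on an aromatic carbon ortho to a large group and two atoms from the ring nitrogen of the shared core. Without a measured step of this kind, the expectation for the step from compound 1 to compound 4 in this assay rests on the values of compound 2 and compound 3 only, both of which carry a phenyl in place of a pyrazine and both of which gave higher numbers than compound 1. The step is expected to be a 1.5-fold higher number from compound 1 to compound 4 (0.18 log units; within the scatter), toward faster clearance, and it may well stay within the scatter. Compound 4 is estimated at 36 mL/min/kg in this assay, in a range from 20 mL/min/kg to 65 mL/min/kg.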

Compound 4, clearance: 17 mL/min/kg
For compound 4 the middle estimate is 2.1-fold (0.33 log units) above the measured one; measured number below the stated range.
By their numbers in this assay, from the lowest: compounds 4, 1, 3 and 2 (each within the scatter of the next, the first and the last beyond it).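

Within the data shown here, the exchange of pyrazin-2-yl for 2-fluorophenyl gives the first step that can be read at this position, on an aromatic carbon ortho to a large group and two atoms from the ring nitrogen: in this assay it is a 1.4-fold lower number from compound 1 to compound 4 (0.15 log units; within the scatter). At this position on the shared core, the read-out therefore does not separate a ring with hetero atoms from a ring of carbon only that carries fluorine, and the nitrogens of pyrazin-2-yl are not needed for a number in this range; the steps linking compound 2 and compound 3 to the other compounds cannot be read, as each such pair differs in more than one place. Nothing measured on these compounds bears on what lies behind this result.

The compounds shown leave open whether the fluorine contributes anything, as an unsubstituted phenyl at this position on the core of compound 1 does not appear among them. They also leave open whether a non-aromatic group here, such as a piperidine or a carboxylic acid, would give a step beyond the scatter.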